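This account rests on a few compounds, and the source may have more. Where it says the series, first, only, none or still open, it means among the compounds named here.

Compound 1 `O=C(NCc1ccc(S(=O)(=O)c2ccccc2)cc1)c1nc2ccncc2s1`: in a functional assay on A2780 cells (Homo sapiens) for inhibition, read by sulforhodamine B assay, with a stated time of 72 h (on this read-out lower numbers stand for stronger inhibition and higher numbers for weaker inhibition), compound 1 gives > 10000 nM, which is a limit of the assay and not a number.
Compound 2 `O=C(Nc1ccc(S(=O)(=O)N2CCCCC2)cc1)c1cc2cnccc2[nH]1`: compound 2 gives > 10000 nM, again a limit.
Compound 3 `O=C(NCc1ccc(S(=O)(=O)N2CCCCC2)cc1)c1ccc2nc[nH]c2c1`: compound 3 gives > 10000 nM, again a limit.

Compound 1 therefore stands nowhere in particular on the numbers shown: its value is only a limit, and the same holds for the other two, as the limit of > 10000 nM in this assay, at which 3 of the 3 values shown sit, records. Within the data shown here, no pair of measured compounds differs in a single place, so no measured step is available.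

Compound 4 `O=C(NCc1ccc(S(=O)(=O)c2ccccc2)cc1)c1cc2cnccc2[nH]1` differs from compound 1 in one place: a group of 9 heavy atoms (7 carbon, 2 nitrogen; one five-membered aromatic ring with 1 hetero atom, one six-membered aromatic ring with 1 hetero atom) in place of a group of 9 heavy atoms (6 carbon, 2 nitrogen, 1 sulfur; one five-membered aromatic ring with 2 hetero atoms, one six-membered aromatic ring with 1 hetero atom), on a carbonyl carbon. Among the measured compounds shown here, the acyl group that enters resembles the one carried by compound 2, whose value is also a limit. On this basis no step beyond the usual scatter is expected in this assay, and the most likely outcome is that compound 4 again reaches only the limit.

Compound 4 is expected to give 15000 nM, within a range from 5000 nM to 50000 nM, which means an estimated step that the limit leaves unreadable from compound 1 to compound 4.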

Compound 4, half-maximal inhibitory concentration: 18 nM
Compound 4: the middle estimate sits 830-fold (2.92 log units) above what was measured, outside the stated range (below it).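

In this assay, among these compounds, the place on the carbonyl carbon proves decisive, which the earlier compounds could not show: exchanging one acyl group for another of equal heavy-atom count gives an at least 550-fold lower number from compound 1 to compound 4 (2.74 log units; beyond the scatter). With this change, sulfur leaves and a hydrogen-bond donor enters. Compound 4 alone among the compounds shown has a value clear of the limit: the limit of > 10000 nM in this assay, at which 3 of the 4 values shown sit.

The compounds shown leave open which of these differences carries the step. They also leave open whether it survives with a methyl group in place of the donor hydrogen.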